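This account rests on a few compounds, and the source may have more. Where it says the series, first, only, none or still open, it means among the compounds named here.

Measured compounds:
compound 1 `CC(C)c1n[nH]c2c(NCc3ccc(-c4ccccn4)cc3)nc(SC(C)C(C)O)nc12` 190 nM
compound 2 `CC(C)c1n[nH]c2c(NCc3ccc(-c4ccccn4)cc3)nc(SCC(C)(C)N)nc12` 85 nM
compound 3 `CC(=O)NCCSc1nc(NCc2ccc(-c3ccccn3)cc2)c2[nH]nc(C(C)C)c2n1` 71 nM

In a functional assay on HT cells (Homo sapiens) for antiproliferative activity, read by fluorescence, with a stated time of 72 h (a higher number here means a weaker inhibitor of growth, a lower number a stronger inhibitor of growth), compound 2 stands second highest of the three numbers. Its nearest neighbour is compound 3, a 1.2-fold lower number from compound 2 to compound 3 (0.08 log units; within the scatter); its furthest is compound 1, a 2.2-fold lower number from compound 1 to compound 2 (0.35 log units; beyond the scatter). Compound 4 `CC(C)c1n[nH]c2c(NCc3ccc(-c4ccccn4)cc3)nc(SC3CCCCC3N)nc12` has not yet been measured. 2-aminocyclohexyl in place of 2-amino-2-methylpropyl on a sulfur Both earlier steps at this sulfur substituent bear on it: a 2.2-fold lower number from compound 1 to compound 2 (0.35 log units; beyond the scatter) and a 1.2-fold lower number from compound 2 to compound 3 (0.08 log units; within the scatter). Since all three measured groups sit within a narrow band, and the amine is kept, compound 4 is expected to move little, a 1.1-fold lower number from compound 2 to compound 4 (0.03 log units; within the scatter), a step within the scatter. Compound 4 is therefore estimated at 80 nM, in the range 35 nM to 200 nM.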

Compound 4, concentration for 50% growth inhibition: 139 nM
Compound 4: the middle estimate sits 1.7-fold (0.24 log units) below what was measured; the measured number falls inside the stated range.
By their numbers in this assay, from the lowest: compounds 3, 2, 4 and 1 (each within the scatter of the next, the first and the last beyond it).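

In this assay, a six-membered carbon ring can stand on the sulfur with its amine kept, and the number stays within the scatter of every earlier compound: a 1.6-fold higher number from compound 2 to compound 4 (0.21 log units; within the scatter), a 2.0-fold higher number from compound 3 to compound 4 (0.29 log units; within the scatter) and a 1.4-fold lower number from compound 1 to compound 4 (0.14 log units; within the scatter). Compound 1 and compound 3 lie beyond the scatter of each other, yet compound 4 lies within the scatter of both, so it does not separate ring from open chain here. No measurement shown explains these numbers.

Open, going by these compounds, is whether a carboxylic acid on the sulfur substituent, or a longer chain ending in an amine, would stay in this range. A smaller ring such as 2-aminocyclopentyl also remains an open case.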